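Replacing the Methylphenyl Group with Thiophene: Expected Cytotoxicity

The compounds below may be only part of what the source reports. "The series", "measured", "known", "first", "only" and "open" are said of these compounds alone.

Compound 1 `Cc1ccc(C2C(C#N)=C(N)N(c3ccc(S(N)(=O)=O)cc3)C3=C2CCCC3)cc1` gives the highest number of the three measured compounds in a functional assay on Ehrlich cells (Mus musculus) for cytotoxicity, read by trypan blue exclusion, with a stated time of 2 h, tested at 50 ug/mL (on this read-out lower numbers stand for a weaker effect and higher numbers for a stronger effect at the one concentration tested), with 80%. Compound 2 `N#CC1=C(N)N(c2ccc(S(N)(=O)=O)cc2)C2=C(CCCC2)C1c1ccc([N+](=O)[O-])cc1` gives 10% and compound 3 `N#CC1=C(N)N(c2ccc(S(N)(=O)=O)cc2)C2=C(CCCC2)C1c1ccc(Cl)c(Cl)c1` gives 50% in this assay. Both measured changes from compound 1 lowered the read-out: a number 70 percentage points lower from compound 1 to compound 2 (beyond the scatter) and a number 30 percentage points lower from compound 1 to compound 3 (beyond the scatter). Compound 4 `N#CC1=C(N)N(c2ccc(S(N)(=O)=O)cc2)C2=C(CCCC2)C1c1cccs1` differs from compound 1 in one place: thiophen-2-yl in place of 4-methylphenyl on a saturated ring carbon. The closest guide is the swap of the aryl group on the saturated ring carbon, which was modest. Compound 4 is therefore expected to give about 50%, within a range from 20% to 80%. This expectation means a number 30 percentage points lower from compound 1 to compound 4 (beyond the scatter), a moderate drop beyond the scatter.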

Compound 4, a percentage reported as activity, at one concentration (the size of the read-out at that concentration, not a potency): 10%
The estimate for compound 4 lay 40 percentage points above the measured number; the measured number lies below the stated range.
By their numbers in this assay, from the lowest: compounds 2 and 4 (each within the scatter of the next); then compound 3; then compound 1.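

At this saturated ring carbon, thiophen-2-yl gives a number 70 percentage points lower from compound 1 to compound 4 (beyond the scatter) and a number 40 percentage points lower from compound 3 to compound 4 (beyond the scatter), so a large fall in the read-out does not require a nitro group. Indeed, there is no change at the digits printed from compound 2 to compound 4 (within the scatter), placing thiophen-2-yl and 4-nitrophenyl level in this assay. Nothing available explains why these two groups give the same result.

As far as these compounds go, it remains open whether the fall follows from the five-membered sulfur-containing ring or from losing the methyl group. Plain phenyl and furan-2-yl at this carbon would help separate these possibilities.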